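The source may hold more compounds than are shown below. What is called first, only, known or untested is meant among the compounds shown, and "the series" means these compounds.

Compound 1 `O=C(Nc1cccc2c(=O)cc(C(=O)O)oc12)c1ccc2ccccc2n1`; compound 2 `COc1ccc(C(=O)Nc2cc(Br)cc3c(=O)cc(C(=O)O)oc23)cn1`; compound 3 `COc1ccc(C(=O)Nc2cccc3c(=O)cc(C(=O)O)oc23)cc1`.

These three compounds share a core and differ in the aryl group attached to the amide carbonyl. In an assay on CHO cells for agonist activity at G-protein coupled receptor 35 (Mus musculus), read by a beta-galactosidase reporter and beta-arrestin recruitment, with a stated time of 90 min (a lower number here means that less compound is needed, a higher number that more compound is needed for the effect), compound 1 gives 3590 nM. In this assay compound 2 gives 4980 nM and compound 3 gives 5030 nM. Compound 2 stands second highest of the three numbers, but its gap to compound 3 and its gap to compound 1 both lie within the usual scatter, so the three values cannot be told apart with confidence.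

Compound 4 `COc1ccccc1C(=O)Nc1cc(Br)cc2c(=O)cc(C(=O)O)oc12` has not yet been measured. It differs from compound 2 in one place: 2-methoxyphenyl in place of 6-methoxypyridin-3-yl on a carbonyl carbon. Because compound 1 gives 3590 nM, compound 2 gives 4980 nM and compound 3 gives 5030 nM despite different aryl groups at this position, the expectation is that the step from compound 2 to compound 4 stays within the scatter, with no clear direction, and the estimated step is a 1.1-fold lower number from compound 2 to compound 4 (0.04 log units; within the scatter). Compound 4 is therefore expected to give about 4500 nM, in the range 1500 nM to 14000 nM.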

Compound 4, half-maximal effective concentration: 4950 nM
Compound 4: middle estimate off by 1.1-fold (0.04 log units), on the low side, within the range that was stated.
By their numbers in this assay, from the lowest: compounds 1, 4, 2 and 3 (each within the scatter of the next).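

In this assay, going by these compounds alone, placing 2-methoxyphenyl on the carbonyl carbon in place of 6-methoxypyridin-3-yl gives a 1.0-fold lower number from compound 2 to compound 4 (0.00 log units; within the scatter) as the first direct comparison at this position, with the rest of the molecule held the same. A six-membered aromatic ring of carbon only and one with a hetero atom therefore cannot be told apart here, even though the methoxy group is also attached differently in the two names. No available measurement explains this result.

The compounds shown leave open whether the number would move if the aromatic ring on the carbonyl carbon gave way to a group of another kind, such as an amine, a carboxylic acid or a longer alkyl chain. Within the data shown here, they also offer no pair that differs only in the bromo group, so its contribution remains unread.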